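The compounds below may be only part of what the source reports. "The series", "measured", "known", "first", "only" and "open" are said of these compounds alone.

Compound 1, `COc1ccc(N2CCN(C)CC2)cc1Nc1ncc(F)c(Nc2ccc(F)cc2)n1`, gives 910 nM in a functional assay on DU-145 cells (Homo sapiens) for antiproliferative activity, read by sulforhodamine B assay, with a stated time of 3 days; a higher number here means a weaker inhibitor of growth, a lower number a stronger inhibitor of growth.
Compound 2, `COc1ccc(NC(=O)c2cccc(Nc3ncc(F)c(Nc4ccc(F)cc4)n3)c2)cc1`, gives > 10000 nM in this assay.

The value of compound 2 in this assay is a limit, not a number (the limit of > 10000 nM in this assay, at which 1 of the 2 values shown sits), so compound 2 stands at the edge of what this assay reports.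

Compound 3 is `O=C(Nc1cc(Cl)cc(Cl)c1)c1cccc(Nc2ncc(F)c(Nc3ccc(F)cc3)n2)c1`. It differs from compound 2 by 3,5-dichlorophenyl in place of 4-methoxyphenyl on an amide-type nitrogen. Going by the values given here, no measured pair shows this change, so the step in this assay cannot be sized from a comparison; the expectation is a step of an at least 1.2-fold lower number from compound 2 to compound 3 (0.09 log units; that floor lies within the scatter) that stays close to the limit, with a real chance that only a limit is reported again. Compound 3 is estimated at 8000 nM, in the range 2000 nM to 30000 nM.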

Compound 3, concentration for 50% growth inhibition: 17500 nM
The estimate for compound 3 lay 2.2-fold (0.34 log units) below the measured number, within the range that was stated.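

Going by these compounds alone, no step from compound 2 to compound 3 can be read in this assay, since compound 2 carries only a limit: the limit of > 10000 nM in this assay, at which 1 of the 3 values shown sits.

The compounds shown leave open how far 3,5-dichlorophenyl in place of 4-methoxyphenyl on an amide-type nitrogen shifts growth inhibition.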